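The source may hold more compounds than are shown below. What is called first, only, known or untested is meant among the compounds shown, and "the series" means these compounds.

Measured in an assay on CHO-K1 cells for antagonist activity at adenosine receptor A1 (Homo sapiens), read by a beta-galactosidase reporter, with stated times of 15 min and 6 h; on this read-out higher numbers stand for weaker inhibition and lower numbers for stronger inhibition:
compound 1 `CC(C)c1ccc(-c2nc(N)c3cc(CN4[C@H](C)CCC[C@@H]4C)sc3n2)o1` — 140 nM
compound 2 `Nc1nc(-c2ncco2)nc2sc(CN3CC=CC3)cc12` — 3890 nM
compound 3 `Nc1nc(-c2ncco2)nc2sc(CN3CC=CCC3)cc12` — 2960 nM

On these numbers compound 3 stands second highest of the three in this assay. Compound 2 lies within the scatter of it, the step being a 1.3-fold lower number from compound 2 to compound 3 (0.12 log units; within the scatter); compound 1 gives a number far lower, beyond the scatter. Compound 4 `Nc1nc(-c2cocn2)nc2sc(CN3CC=CCC3)cc12` keeps the same atoms joined differently: 1,3-oxazol-4-yl in place of 1,3-oxazol-2-yl on an aromatic carbon. Going by the values given here, no measured step touches this attachment point; the only step available, a 1.3-fold lower number from compound 2 to compound 3 (0.12 log units; within the scatter), concerns the other end of the molecule and is itself within the scatter. With nothing to lean on, compound 4 is expected to give a step of a 1.0-fold higher number from compound 3 to compound 4 (0.01 log units; within the scatter), none beyond the scatter. Compound 4 is therefore estimated at 3000 nM, with a range from 1000 nM to 10000 nM.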

Compound 4, inhibition constant: 2960 nM
The estimate for compound 4 lay 1.0-fold (0.01 log units) above the measured number; measured number inside the range.
By their numbers in this assay, from the lowest: compound 1; then compounds 3, 4 and 2 (each within the scatter of the next).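

At the aromatic carbon between two ring nitrogen atoms, the first measured exchange is 1,3-oxazol-4-yl in place of 1,3-oxazol-2-yl, and in this assay it reads as no change at the digits printed from compound 3 to compound 4 (within the scatter). With the rest of the molecule held fixed, this assay does not tell the two oxazole attachments apart. No measured evidence bears on this result.

Open, going by these compounds, is whether this position responds at all to a different group, such as a phenyl ring or a carboxylic acid. Also open, on these data alone, is whether the oxazole exchange reads the same with another amine at the far end of the molecule.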